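Swapping the Benzoyl Group: From Compound 3 to Compound 4

The source may hold more compounds than are shown below. What is called first, only, known or untested is meant among the compounds shown, and "the series" means these compounds.

Compound 1 `COc1cc2ncnc(Nc3ccc(NC(=O)c4ccc(C)cc4)cc3)c2cc1OC`: 25000 nM
Compound 2 `COc1cc2ncnc(Nc3ccc(NC(=O)c4ccccc4OC)cc3)c2cc1OC`: > 100000 nM
Compound 3 `COc1cc2ncnc(Nc3ccc(NC(=O)c4cccc(Cl)c4)cc3)c2cc1OC`: 12000 nM

Among the measured compounds shown here, in a functional assay on HepG2 cells (Homo sapiens) for inhibition, read by MTT assay (a lower number here means a stronger inhibitor, a higher number a weaker inhibitor), compound 3 gives 12000 nM, the lowest of the exact numbers so far. Compound 2 is reported only as a limit, > 100000 nM.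

Compound 4 `COc1cc2ncnc(Nc3ccc(NC(=O)c4c(F)cccc4F)cc3)c2cc1OC` keeps the rest of compound 3 and changes one group: 2,6-difluorophenyl in place of 3-chlorophenyl on a carbonyl carbon. All three measured steps change this same group on a carbonyl carbon. The step of a 2.1-fold lower number from compound 1 to compound 3 (0.32 log units; beyond the scatter) is modest. The steps of an at least 4.0-fold higher number from compound 1 to compound 2 (0.60 log units; beyond the scatter) and an at least 8.3-fold lower number from compound 2 to compound 3 (0.92 log units; beyond the scatter) are larger, so this position can clearly move the number.

Among the measured groups, the 2-methoxyphenyl of compound 2 is the only one numbered like the entering 2,6-difluorophenyl, and an at least 8.3-fold lower number from compound 2 to compound 3 (0.92 log units; beyond the scatter) points to a cost in leaving the 3-chlorophenyl. With so few compounds, this is only a weak guide. The expected change is a 2.5-fold higher number from compound 3 to compound 4 (0.40 log units; beyond the scatter), towards weaker inhibition.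

Compound 4 is expected at about 30000 nM, with an estimated range of 9000 nM to 100000 nM.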

Compound 4, half-maximal inhibitory concentration: 17000 nM
For compound 4 the middle estimate is 1.8-fold (0.25 log units) above the measured one; measured number inside the range.
By their numbers in this assay, from the lowest: compounds 3, 4 and 1 (each within the scatter of the next, the first and the last beyond it). At a limit, above all of these: compound 2.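

Putting in the 2,6-difluorophenyl gives a 1.4-fold higher number from compound 3 to compound 4 (0.15 log units; within the scatter) and a 1.5-fold lower number from compound 1 to compound 4 (0.17 log units; within the scatter), so in this assay this group cannot be told apart from the 3-chlorophenyl or the 4-methylphenyl. The 2-methoxyphenyl of compound 2 stands apart, with an at least 5.8-fold lower number from compound 2 to compound 4 (0.76 log units; beyond the scatter), which shows that a substituent numbered 2 on the phenyl is not enough on its own to bring the loss seen with compound 2. That step has a limit at one end and not an exact number: the limit of > 100000 nM in this assay, at which 1 of the 4 values shown sits.

The compounds shown do not tell why the 2-methoxyphenyl differs from the other groups. They also leave open whether an amine or a carboxylic acid on this phenyl, or a longer chain in its place, would move the number in either direction.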